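A few compounds are considered here, and "the series" means these few. Any claim that something is new, unique, unknown or untested is made for them only; others in the source may bear on it.

Measured compounds in an assay on HEK293 cells for positive allosteric modulation of metabotropic glutamate receptor 3 (Rattus norvegicus), read by thallium flux, with a stated time of 2.5 min; a lower number here means a smaller maximal response, a higher number a larger maximal response:
- Compound 1, `Cc1c(OCCCCOc2ccc(C(=O)O)cc2)ccc(C(=O)CC2CCCC2)c1O`, gives 26.7%.
- Compound 2, `Cc1cc(C(=O)O)ccc1OCCCCOc1ccc(C(=O)CC(C)C)c(O)c1C`, gives 42.1%.
- Compound 3, `CCCC(=O)c1ccc(OCCCCOc2ccc(F)c(C(=O)O)c2)c(C)c1O`, gives 56.9%.

Compound 1 stands lowest of the three numbers. Compound 2 lies above it by a margin beyond the usual scatter, and compound 3 lies further above, also beyond the scatter. No two of these compounds differ in a single place, so none of these gaps can be tied to one structural change; they only show that compound 1 is the weakest responder of the measured set.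

Compound 4, `Cc1c(OCCCCOc2ccc(C(=O)O)cc2Cl)ccc(C(=O)CC2CCCC2)c1O`, differs from compound 1 as follows: chloro in place of hydrogen on an aromatic carbon. Everything else, the acyl chain, the linker and the carboxy group, stays as in compound 1.

Within the data shown here, no comparable single step is available among the measured compounds, so the size of this step is open. With compound 1 at 26.7% in this assay, the expectation is a small upward move, most likely within the usual scatter, with a downward outcome not excluded. The expected step is a number 6.3 percentage points higher from compound 1 to compound 4 (within the scatter). Compound 4 is estimated at 33%, in a range from 18% to 52%.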

Compound 4, largest response reached (reported as percent of maximum), in percent of the reference or control that the assay uses: 27.4%
Compound 4: middle estimate off by 5.6 percentage points, on the high side, and the stated range covers the measured number.
By their numbers in this assay, from the lowest: compounds 1 and 4 (each within the scatter of the next); then compound 2; then compound 3.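

In this assay the series gains its first single-place comparison: a number 0.7 percentage points higher from compound 1 to compound 4 (within the scatter) for chloro in place of hydrogen on an aromatic carbon, ortho to a large group and meta to a carboxy group. The change from 4-carboxyphenyl to 4-carboxy-2-chlorophenyl is therefore tolerated at this position, with the acyl chain, linker and carboxy group held as in compound 1, although this is one substituent on one background and the gaps to compounds 2 and 3 cannot be read as steps. No measurement on hand bears on the reason for this outcome.

Still open, on these data alone, is whether this position stays equally flat with a bromo, a methoxy or an amine in place of the chloro, or whether any such group would move the maximal response beyond the scatter. Also open, as far as these compounds go, is whether the same chloro gives the same result with a longer acyl chain or a longer linker chain, since here it has been read only against the acyl chain of compound 1.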